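The source may hold more compounds than are shown below. What is called first, only, known or untested is meant among the compounds shown, and "the series" means these compounds.

Measured so far:
- compound 1 `Cc1cc(O)c(C(C)C)cc1-c1cc(-c2ccccc2[N+](=O)[O-])c(C#N)c(=O)[nH]1`: 37.5%
- compound 2 `Cc1cc(O)c(C(C)C)cc1-c1cc(-c2ccccc2Cl)c(C#N)c(=O)[nH]1`: 34%

In a functional assay for inhibition, tested at 100 ug/mL (on this read-out higher numbers stand for a stronger effect at the one concentration tested and lower numbers for a weaker effect), compound 1 gives 37.5%, nominally the higher of the two numbers, but the step of a number 3.5 percentage points lower from compound 1 to compound 2 (within the scatter) is within the scatter, so the two compounds cannot be told apart. Compound 3 `COc1cccc(-c2cc(-c3cc(C(C)C)c(O)cc3C)[nH]c(=O)c2C#N)c1` differs from compound 1 by 3-methoxyphenyl in place of 2-nitrophenyl on an aromatic carbon. Among the compounds with values here, the only measured step exchanged a group at this same place and stayed within the scatter, so no shift beyond the scatter is expected here either; the estimated step of a number 2.5 percentage points lower from compound 1 to compound 3 (within the scatter) is small. Compound 3 is therefore expected to give about 35%, between 20% and 50%.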

Compound 3, a percentage reported as inhibition, at one concentration (the size of the read-out at that concentration, not a potency): 49%
Beside the measured number, compound 3's estimate is 14 percentage points below it, within the range that was stated.
By their numbers in this assay, from the lowest: compounds 2 and 1 (each within the scatter of the next); then compound 3.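

In this assay, replacing 2-nitrophenyl with 3-methoxyphenyl gives a number 11.5 percentage points higher from compound 1 to compound 3 (beyond the scatter), and replacing 2-chlorophenyl with it gives a number 15 percentage points higher from compound 2 to compound 3 (beyond the scatter). So an exchange at this position, opposite the ring nitrogen, can move the read-out beyond the scatter, which the step between compound 1 and compound 2 did not show. No measurement here explains this rise.

The compounds shown leave open whether the methoxy group or its place on the phenyl ring matters. Going by these compounds, how a phenyl ring carrying an amine or a carboxylic acid would compare also remains open.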